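The source may report more compounds than this note shows. Statements on the series, on what has been measured and on what is new or still open speak of the compounds shown alone.

In a functional assay on BXPC-3 cells (Homo sapiens) for inhibition, read by MTT assay, with a stated time of 7 days (a lower number here means a stronger inhibitor, a higher number a weaker inhibitor), the measured compounds give these values:

compound 1 `O=C([C@@H]1CCCN(S(=O)(=O)c2ccc(S(=O)(=O)N3CC[C@@H](O)C3)cc2)C1)N1CCC(F)(F)CC1`: 330 nM
compound 2 `CCN(CC)S(=O)(=O)c1ccc(S(=O)(=O)N2CCC[C@@H](C(=O)NC3COC3)C2)cc1`: 13800 nM
compound 3 `O=C([C@@H]1CCCN(S(=O)(=O)c2ccc(S(=O)(=O)C3CC3)cc2)C1)N1CCC(F)(F)CC1`: 129 nM

Of these three, compound 2 has the highest number, and the values of compound 1 and compound 3 lie well under it. Compound 4 `CCN(CC)S(=O)(=O)c1ccc(S(=O)(=O)N2CCC[C@@H](C(=O)N[C@H]3CC[C@@H](OC)CC3)C2)cc1` differs from compound 2 in one place: 4-methoxycyclohexyl in place of oxetan-3-yl on an amide-type nitrogen, in words 4-methoxycyclohexyl in place of oxetan-3-yl on an amide-type nitrogen.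

Within the data shown here, no measured step covers this change. Among the measured compounds shown here, the only step available, a 2.6-fold lower number from compound 1 to compound 3 (0.41 log units; beyond the scatter), is modest and concerns cyclopropyl in place of 3-hydroxypyrrolidin-1-yl on a sulfonyl sulfur. That is a different place, so it offers only a rough idea of how far a single group exchange can move the number in this series. Compound 2 differs from compound 1 and compound 3 in more than one place, so their values give no direct guide.

For the measured compounds named here, with compound 2 at 13800 nM as the top value so far, a lower number in this assay seems more likely than a higher one, though this expectation is weakly supported. Going by the values given here, the expected change is a 3.5-fold lower number from compound 2 to compound 4 (0.54 log units; beyond the scatter), somewhat larger than the one measured step. For compound 4 the estimated value is 4000 nM, with an expected range from 600 nM to 20000 nM as its bounds.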

Compound 4, half-maximal inhibitory concentration: 2150 nM
Compound 4: the middle estimate sits 1.9-fold (0.27 log units) above what was measured; measured number inside the range.
By their numbers in this assay, from the lowest: compound 3; then compound 1; then compound 4; then compound 2.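

In this assay, the group on the amide-type nitrogen proves to be a place where a single exchange moves the number, with 4-methoxycyclohexyl in place of oxetan-3-yl giving a 6.4-fold lower number from compound 2 to compound 4 (0.81 log units; beyond the scatter). Among these compounds, the earlier compounds offered no step at this position, and the only other measured step lies on a sulfonyl sulfur, so this is the first direct reading here: the entering group has more heavy atoms and a six-membered carbon ring, while the hydrogen-bond donor and acceptor counts stay the same, which shows that the number can fall without a change in those counts. No measurement among the data shown accounts for the step or separates the part played by ring size from that of the methoxy group.

From the compounds shown here alone, what remains open is whether plain cyclohexyl, without the methoxy group, would give a similar number, and whether the other stereoisomer of 4-methoxycyclohexyl would match compound 4. An amine or a carboxylic acid on that ring, or an open chain such as butyl on the same nitrogen, also remains untested in the compounds shown here.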